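This account rests on a few compounds, and the source may have more. Where it says the series, first, only, none or still open, it means among the compounds named here.

Series notes. Three analogues carry numbers in an assay on CHO-K1 cells for displacement of a labelled ligand from melanin-concentrating hormone receptor 1 (Homo sapiens), read by scintillation proximity assay, with a stated time of 2 h; a higher number here means a weaker inhibitor, a lower number a stronger inhibitor. Compound 1 `C/C(=C\C(=O)Nc1ccc2nc(N3CCC(O)CC3)nc(C)c2c1)c1ccc(Cl)cc1` gives 670 nM and compound 3 `Cc1nc(N2CCC(O)(C3CC3)CC2)nc2ccc(NC(=O)/C=C/c3ccc(Cl)cc3Cl)cc12` gives 620 nM, while compound 2 `Cc1nc(N2CCC(N3CCOC3=O)CC2)nc2ccc(NC(=O)/C=C/c3ccc(OC(F)(F)F)cc3)cc12` gives 41 nM, the lowest of the three, with gaps to compound 1 and to compound 3 that both lie beyond the usual scatter. Compound 4 `Cc1nc(NCCNS(C)(=O)=O)nc2ccc(NC(=O)/C=C/c3ccc(OC(F)(F)F)cc3)cc12` has not yet been measured in this assay. It differs from compound 2 in one place: (2-(methanesulfonamido)ethyl)amino in place of 4-(2-oxo-1,3-oxazolidin-3-yl)piperidin-1-yl on an aromatic carbon. Within the data shown here, no measured pair shows a step of this kind, so the size of the change is open. The step from compound 2 to compound 4 is expected to be a 6.1-fold higher number from compound 2 to compound 4 (0.79 log units; beyond the scatter) toward a weaker inhibitor, beyond the scatter. Compound 4 is therefore estimated at 250 nM, within a range from 60 nM to 1000 nM.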

Compound 4, half-maximal inhibitory concentration: 169 nM
The estimate for compound 4 lay 1.5-fold (0.17 log units) above the measured number; the range from low to high includes it.
By their numbers in this assay, from the lowest: compound 2; then compound 4; then compounds 3 and 1 (each within the scatter of the next).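

In this assay, among these compounds, the position between two ring nitrogen atoms gives the series its only single-place step: (2-(methanesulfonamido)ethyl)amino in place of 4-(2-oxo-1,3-oxazolidin-3-yl)piperidin-1-yl yields a 4.1-fold higher number from compound 2 to compound 4 (0.62 log units; beyond the scatter) and is a modest change. The substituent here therefore need not contain a ring for binding to remain measurable, although the open chain gives up some of the inhibition seen with compound 2. The compounds shown do not separate the loss of both rings from the arrival of the methanesulfonamido group, so a piperidin-1-yl carrying that group would be the informative comparison. No measurement at hand gives a reason for the step.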